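Side-chain swap from carboxy to cyanomethyl

This account rests on a few compounds, and the source may have more. Where it says the series, first, only, none or still open, it means among the compounds named here.

Read-out: a functional assay on A 172 cells (Homo sapiens) for cytotoxicity, read by colorimetric assay and MTT assay; on this read-out lower numbers stand for stronger inhibition and higher numbers for weaker inhibition
Compound 1 `CCN(CC)C(=O)Cn1c(=O)c(-c2ccc(OC)cc2)cc2c(OC)cc(OC)cc21` gives 10000 nM
Compound 2 `COc1ccc(-c2cc3c(OC)cc(OC)cc3n(CC#N)c2=O)cc1` gives 10000 nM
Compound 3 `COc1ccc(-c2cc3c(OC)cc(OC)cc3n(CC(=O)O)c2=O)cc1` gives 10000 nM

Alongside compound 1 and compound 2, compound 3 sits level at 10000 nM and has no measured advantage or deficit. The next structure is compound 4 `COc1ccc(-c2cc3c(OC)cc(OC)cc3n(CCC#N)c2=O)cc1` and the change is cyanomethyl in place of carboxy on a saturated chain carbon bound to an aromatic nitrogen. In words, this is cyanomethyl in place of carboxy on a saturated chain carbon bound to an aromatic nitrogen. Among the compounds with values here, three measured steps bear on it: no change at the digits printed from compound 2 to compound 3 (within the scatter) and no change at the digits printed from compound 1 to compound 2 (within the scatter) and no change at the digits printed from compound 1 to compound 3 (within the scatter). With all three within the scatter, no step beyond the scatter is expected in this assay in either direction. The expected change is no change at the digits printed from compound 3 to compound 4 (within the scatter). For compound 4 the estimated value is 10000 nM with an expected range from 5000 nM to 20000 nM.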

Compound 4, half-maximal inhibitory concentration: 10000 nM
Compound 4: the middle estimate sits on the measured number at the digits printed; the measured number falls inside the stated range.
By their numbers in this assay, from the lowest: compounds 1, 2, 3 and 4 (each within the scatter of the next).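

this assay shows no change at the digits printed from compound 3 to compound 4 (within the scatter) and no change at the digits printed from compound 2 to compound 4 (within the scatter) and no change at the digits printed from compound 1 to compound 4 (within the scatter) at this place, a saturated chain carbon bound to an aromatic nitrogen. The 2-cyanoethyl group of compound 4 therefore adds a fourth side chain on the shared core, and none of the four separates from the others. No supporting evidence bears on this result. As far as these compounds go, whether an amine, a morpholine or a longer chain at this place would give a step beyond the scatter stays open, as does any effect of changing the methoxy groups on the core.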